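The compounds below may be only part of what the source reports. "The series", "measured", "known", "first", "only" and "open" are said of these compounds alone.

Measured compounds:
compound 1 `Cc1cc(N(C)C)nc2ccc(NC(=O)c3ccc(Cl)c(Cl)c3)cc12`: 33300 nM
compound 2 `Cc1cc(NCCN2CCCCC2)nc2ccc(NC(=O)c3ccc(Cl)c(Cl)c3)cc12`: 1190 nM

Among the measured compounds shown here, in a functional assay on MCF7 cells (Homo sapiens) for antiproliferative activity, read by MTT assay, with a stated time of 72 h (a lower number here means a stronger inhibitor, a higher number a weaker inhibitor), compound 2 gives the lowest of the two numbers so far, and compound 1 sits well apart from it. For the measured compounds named here, the only step within the measured pair, a 28-fold lower number from compound 1 to compound 2 (1.45 log units; beyond the scatter), describes the replacement of dimethylamino by (2-(piperidin-1-yl)ethyl)amino at the same aromatic carbon.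

Compound 3 `CCN(CC)c1cc(C)c2cc(NC(=O)c3ccc(Cl)c(Cl)c3)ccc2n1` differs from compound 2 by diethylamino in place of (2-(piperidin-1-yl)ethyl)amino on an aromatic carbon. This undoes much of what the measured step added: compound 3 carries a dialkylamino group with no ring and no hydrogen-bond donor, closer in its counted features to compound 1 than to compound 2. The relevant precedent is therefore a 28-fold lower number from compound 1 to compound 2 (1.45 log units; beyond the scatter), read in reverse. A large rise in the number in this assay is expected for compound 3, though diethylamino is not identical to dimethylamino, so the return need not be complete. Compound 3 is expected to give about 15000 nM, within 4000 nM to 45000 nM, meaning an estimated step of a 13-fold higher number from compound 2 to compound 3 (1.10 log units; beyond the scatter).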

Compound 3, half-maximal inhibitory concentration: > 50000 nM
Compound 3: only a limit was reported; the forecaster's own chance of this, stated with the estimate: 10%; at least 3.3-fold (0.52 log units) between middle value and limit.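

In this assay compound 3 gives > 50000 nM, which is a limit of the assay and not a number. With diethylamino on this aromatic carbon next to the ring nitrogen, the step is an at least 42-fold higher number from compound 2 to compound 3 (1.62 log units; beyond the scatter), so the low number of compound 2 is now set apart from two dialkylamino groups rather than from dimethylamino alone. Against dimethylamino, the step is an at least 1.5-fold higher number from compound 1 to compound 3 (0.17 log units; that floor lies within the scatter); its floor lies within the scatter, so these two groups cannot be ranked.

As far as these compounds go, it remains open which part of (2-(piperidin-1-yl)ethyl)amino goes with the lower number: the amino hydrogen, the ethyl chain or the piperidine ring. A 2-(dimethylamino)ethylamino group, which keeps the chain without the ring, or a morpholine ring in place of piperidine would help separate these parts.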